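The source may report more compounds than this note shows. Statements on the series, on what has been measured and on what is new or still open speak of the compounds shown alone.

The measured compounds and their numbers:
compound 1, `CC1=C(/C=C/C(=O)/C=C/c2ccccc2)C(C)(C)CCC1` — 62200 nM
compound 2, `CC1=C(/C=C/C(=O)/C=C/c2ccc(Br)cc2)C(C)(C)CCC1` — 34500 nM
compound 3, `CC1=C(/C=C/C(=O)/C=C/c2ccc(C#N)cc2)C(C)(C)CCC1` — 45600 nM

All three were read in a functional assay on Hep cells (Homo sapiens) for cytotoxicity, read by sulforhodamine B assay, with a stated time of 48 h; on this read-out lower numbers stand for stronger inhibition and higher numbers for weaker inhibition. Compound 3 stands second highest of the three numbers. Its nearest neighbour is compound 2, and a 1.3-fold higher number from compound 2 to compound 3 (0.12 log units; within the scatter). The furthest is compound 1, and a 1.4-fold lower number from compound 1 to compound 3 (0.13 log units; within the scatter). The remaining pair shows a 1.8-fold lower number from compound 1 to compound 2 (0.26 log units; within the scatter). Every step among the measured compounds thus lies within the scatter of repeated readings.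

Compound 4, `CC1=C(/C=C/C(=O)/C=C/c2ccc([N+](=O)[O-])cc2)C(C)(C)CCC1`, differs from compound 3 in one place: nitro in place of cyano on an aromatic carbon. Of the measured steps, only a 1.3-fold higher number from compound 2 to compound 3 (0.12 log units; within the scatter) exchanges one group for another at this place, and the two others put a group where hydrogen stood, both within the scatter as well. None of them involves a nitro group, so the bearing of these steps on compound 4 is indirect. The data give no ground to expect a step beyond the scatter in this assay in either direction. The estimated step for compound 4 is accordingly a 1.0-fold lower number from compound 3 to compound 4 (0.01 log units; within the scatter). For compound 4 the expected number in this assay is 45000 nM, with a range from 20000 nM to 95000 nM.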

Compound 4, half-maximal inhibitory concentration: 55500 nM
Compound 4: the middle estimate sits 1.2-fold (0.09 log units) below what was measured, and the stated range covers the measured number.
By their numbers in this assay, from the lowest: compounds 2, 3, 4 and 1 (each within the scatter of the next).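

In this assay, for the compounds shown here, the aromatic carbon para to a large group has now carried hydrogen, bromo, cyano and nitro, and nitro, the only one of these groups with oxygen atoms and with 2 hydrogen-bond acceptors, stays within the scatter of the other three: nitro in place of cyano gives (a 1.2-fold higher number from compound 3 to compound 4 (0.09 log units; within the scatter)), nitro in place of bromo gives (a 1.6-fold higher number from compound 2 to compound 4 (0.21 log units; within the scatter)), and nitro in place of hydrogen gives (a 1.1-fold lower number from compound 1 to compound 4 (0.05 log units; within the scatter)). The flat picture that the first three compounds gave at this place therefore holds for a group of a different atomic make-up, and across all four compounds no group stands apart from any other beyond the scatter. Nothing available explains why these readings lie so close together.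

From the compounds shown here alone, whether an amine, a carboxylic acid or a hydroxyl group at this place would give a step beyond the scatter remains open. Also open, going by these compounds, is whether a bromo or nitro group on another carbon of the same aromatic ring, or a change to the shared core, would move the number more than any exchange seen here.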